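Trifluoromethyl in Place of Hydrogen: Expecting Little Change

A few compounds are considered here, and "the series" means these few. Any claim that something is new, unique, unknown or untested is made for them only; others in the source may bear on it.

Compound 3 `O=C1C=CCC(/C=C/c2ccccc2)N1` is the weakest growth inhibitor of the three measured compounds: in a functional assay on NCI-H460 cells (Homo sapiens) for inhibition, read by sulforhodamine B assay, with a stated time of 48 h (a lower number here means a stronger inhibitor of growth, a higher number a weaker inhibitor of growth), compound 3 gives 929 uM. Compound 1 `O=C1C=COC(/C=C/c2ccccc2)C1` gives 82.4 uM, and compound 2 `COc1ccc(/C=C/C2CC(=O)C=CO2)cc1` gives 149 uM, both beyond the scatter from compound 3. Compound 4 `O=C1C=CCC(/C=C/c2ccccc2C(F)(F)F)N1` differs from compound 3 by trifluoromethyl in place of hydrogen on an aromatic carbon. Going by the values given here, the only measured step that bears on a change on an aromatic carbon is a 1.8-fold higher number from compound 1 to compound 2 (0.26 log units; within the scatter), a change with no effect beyond the scatter. A trifluoromethyl group is not a methoxy, but nothing measured here separates them, so compound 4 is expected to stay close, with an estimated step of a 1.0-fold lower number from compound 3 to compound 4 (0.01 log units; within the scatter). Compound 4 is therefore estimated at 900 uM, with a range from 300 uM to 2500 uM.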

Compound 4, concentration for growth inhibition (reported as GI): 195 uM
The estimate for compound 4 lay 4.6-fold (0.66 log units) above the measured number; measured number below the stated range.
By their numbers in this assay, from the lowest: compounds 1, 2 and 4 (each within the scatter of the next, the first and the last beyond it); then compound 3.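

In this assay, trifluoromethyl in place of hydrogen on an aromatic carbon, ortho to a group of 9 heavy atoms, gives a 4.8-fold lower number from compound 3 to compound 4 (0.68 log units; beyond the scatter), a modest step but one beyond the scatter. Going by these compounds alone, the earlier compounds showed no such effect, so this result is the first sign that a change on the aromatic ring can move this number. Nothing measured here gives a reason for the step.

On these data alone, it remains open whether an amine or a carboxylic acid at this same place would lower the number too. Also open, as far as these compounds go, is whether trifluoromethyl would do the same on the core of compound 1.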